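The compounds below may be only part of what the source reports. "The series", "measured", "known", "first", "only" and "open" are said of these compounds alone.

Measured compounds in a functional assay on MCF7 cells (Homo sapiens) for antiproliferative activity, read by MTT assay, with a stated time of 24 h; on this read-out higher numbers stand for weaker inhibition and lower numbers for stronger inhibition:
- compound 1 `COc1ccc(-c2noc(-c3ccccc3)n2)cc1OC1CCCC1`: > 1000000 nM, a limit of the assay and not a number.
- compound 2 `COc1cc(-c2noc(-c3ccncc3)n2)ccc1OCc1ccccc1`: > 1000000 nM, likewise a limit.
- compound 3 `COc1ccc(-c2noc(Cc3c[nH]c4ccccc34)n2)cc1OC1CCCC1`: > 1000000 nM, likewise a limit.

Compound 1 stands where every other measured compound stands, at the limit of > 1000000 nM in this assay, at which 3 of the 3 values shown sit. Among the compounds with values here, no pair of measured compounds differs in one place, so no measured step is available, and nothing in the numbers separates any of the three compounds from the others.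

Compound 4 `COc1ccc(-c2noc(C3CCCN3)n2)cc1OC1CCCC1` differs from compound 1 by pyrrolidin-2-yl in place of phenyl on an aromatic carbon. With all three measured values sitting at the limit, the numbers give no direction for this change. The step from compound 1 is therefore expected to be a number no higher from compound 1 to compound 4 (the limit leaves the size open), which is none beyond the scatter, because of the limit of > 1000000 nM in this assay, at which 3 of the 3 values shown sit. In this assay compound 4 is expected to give about 1000000 nM, with the range 200000 nM to 3000000 nM, and most likely to be reported again only as a limit rather than as a number.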

Compound 4, half-maximal inhibitory concentration: > 1000000 nM
Compound 4 ended at the assay's limit; the forecaster's own chance of this, stated with the estimate: 70%; the middle value lies on the limit itself.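

No step can be read between compound 1 and compound 4, since both values are limits and not numbers: the limit of > 1000000 nM in this assay, at which 4 of the 4 values shown sit.

The compounds shown leave open which change to the core of compound 1, if any, would give a numerical value in this assay.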